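The compounds below may be only part of what the source reports. "The series", "measured", "known", "first", "only" and "open" are said of these compounds alone.

Among the compounds with values here, in a functional assay on MDA-MB-468 cells (Homo sapiens) for inhibition, read by MTT assay (a lower number here means a stronger inhibitor of growth, a higher number a weaker inhibitor of growth), compound 1 `CC1=C(/C=C/C(C)=C/C=C/C(C)=C\C(=O)Nc2cccc(F)c2)C(C)(C)CCC1n1ccnc1` gives 6760 nM, the lowest of the three numbers measured so far. Compound 2 `CC1=C(/C=C/C(C)=C/C=C/C(C)=C\C(=O)NCc2ccc(O)cc2)C(C)(C)CC=C1c1cncnc1` gives 19100 nM and compound 3 `CC1=C(/C=C/C(C)=C/C=C/C(C)=C\C(=O)Nc2ccccc2)C(C)(C)CC=C1c1cncnc1` gives 22900 nM. Both lie beyond the scatter from compound 1 and within the scatter of each other.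

The change under review leads to compound 4 `CC1=C(/C=C/C(C)=C/C=C/C(C)=C\C(=O)Nc2ccccc2O)C(C)(C)CCC1n1ccnc1`, with 2-hydroxyphenyl in place of 3-fluorophenyl on an amide-type nitrogen. The core and the rest of compound 1 stay as they are.

Within the data shown here, only one measured step bears on this place: a 1.2-fold higher number from compound 2 to compound 3 (0.08 log units; within the scatter), which stays within the scatter. That step is phenyl in place of 4-hydroxybenzyl on an amide-type nitrogen, so it involves neither group of the present change. The core of compound 2 also differs from the core of compound 1, which makes this thin evidence. Among the measured compounds shown here, no measured pair tests the 2-hydroxyphenyl group.

No step beyond the scatter is therefore expected in this assay, and no direction is favoured. The estimated change is a 1.1-fold higher number from compound 1 to compound 4 (0.05 log units; within the scatter). For compound 4 the expected value is 7500 nM, with an estimated range of 3000 nM to 19000 nM.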

Compound 4, concentration for 50% growth inhibition: 3030 nM
Estimate against measurement, compound 4: 2.5-fold (0.39 log units) above; measured number inside the range.
By their numbers in this assay, from the lowest: compound 4; then compound 1; then compounds 2 and 3 (each within the scatter of the next).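

In this assay, the substituent on the amide-type nitrogen is now seen to matter on the core of compound 1: a 2.2-fold lower number from compound 1 to compound 4 (0.35 log units; beyond the scatter). Within the data shown here, the only earlier step at this place stayed within the scatter, involved neither of these groups and lay on a different core, so it gave no sign that this position could respond. Here 3-fluorophenyl gives way to 2-hydroxyphenyl, so the fluorine leaves and the hydroxyl enters in one change, and nothing available explains the step or assigns it to either group.

Going by these compounds, it remains open whether the hydroxyl itself is needed, which a methoxy or an amine in its place would help to settle. On these data alone, it also remains open whether the same step would appear on the core shared by compound 2 and compound 3.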